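Replacing Pentyl with 2-Ethoxyethoxy on a Shared Core

The compounds below may be only part of what the source reports. "The series", "measured", "known", "first", "only" and "open" are said of these compounds alone.

Compound 1 `CCCCCC(=O)Nc1cc2nc(C3CCCCC3)[nH]c2cc1N1CCCC1` carries a pentylcarbonyl amide on its shared core. In an ADME assay on Vero cells (Chlorocebus sabaeus) for cytotoxicity, read by resazurin assay, with a stated time of 3 days (on this read-out higher numbers stand for weaker inhibition and lower numbers for stronger inhibition), compound 1 gives only a limit, > 100 ug/mL, not a number. Compound 3 `CCCc1ccc(C(=O)Nc2cc3nc(C4CCCCC4)[nH]c3cc2N(C)C)cc1` likewise gives only a limit in this assay, > 100 ug/mL. Compound 2 `CCCCCC(=O)Nc1cc2nc(C3CCCCC3)[nH]c2cc1N(CC)CC` has no result in this assay, "not determined" (no result reported). Compound 1 therefore stands at the limit of this assay, where two of the three entries sit (the limit of > 100 ug/mL in this assay, at which 2 of the 3 values shown sit), and no single number is known for it.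

Compound 4 `CCOCCOC(=O)Nc1cc2nc(C3CCCCC3)[nH]c2cc1N1CCCC1` differs from compound 1 in one place: 2-ethoxyethoxy in place of pentyl on a carbonyl carbon. Among the measured compounds shown here, no pair of measured compounds shows what such a swap does in this assay. With both measured values sitting at the limit (the limit of > 100 ug/mL in this assay, at which 2 of the 3 values shown sit), the step from compound 1 to compound 4 is expected to stay within the scatter, a step that the limit leaves unreadable from compound 1 to compound 4. Compound 4 is thus expected to give 120 ug/mL in this assay, between 50 ug/mL and 300 ug/mL, most likely reported again only as a limit.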

Compound 4, half-maximal inhibitory concentration: > 100 ug/mL
Compound 4 was reported as a limit (the forecaster's own chance of this, stated with the estimate: 80%); the middle value does not contradict the limit.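

Among the compounds shown here, compound 1 and compound 4 both give only a limit in this assay, so no step between them can be read: the limit of > 100 ug/mL in this assay, at which 3 of the 4 values shown sit.

Still open, going by these compounds, is whether 2-ethoxyethoxy in place of pentyl on a carbonyl carbon changes cytotoxicity at all, since neither compound has a single number in this assay.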